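The compounds below may be only part of what the source reports. "The series", "measured", "known", "first", "only" and "open" are said of these compounds alone.

In a functional assay on A549 cells (Homo sapiens) for cytotoxicity, read by sulforhodamine B assay, with a stated time of 48 h (on this read-out lower numbers stand for stronger inhibition and higher numbers for weaker inhibition), two compounds have been measured so far. Compound 1 (`COc1ccc(/C=C/C(=O)c2ccc(NC(C)=O)c(-c3ccc(F)cc3)c2)cc1OC`) gives 7380 nM and compound 2 (`O=C(/C=C/c1cccc(-c2ccc(F)cc2)c1)c1ccc(O)cc1`) gives 8360 nM in the same test. Within the data shown here, these two values lie within the scatter of each other, so compound 1 stands level with the only other measured compound and neither can be ranked. Among the measured compounds shown here, their structures differ in more than one place, and no single-change step is available from the data.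

Compound 3 (`COc1ccc(/C=C/C(=O)c2cccc(-c3ccc(F)cc3)c2)cc1OC`) has yet to be measured in this assay and is compared here with compound 1. It carries hydrogen in place of acetamido on an aromatic carbon, ortho to a 4-fluorophenyl group and para to a large group (hydrogen in place of acetamido on an aromatic carbon).

Compound 2 has no acetamido group, yet it gives 8360 nM and so sits within the scatter of compound 1. On that limited evidence, no change beyond the scatter is expected in either direction. The estimated step is a 1.2-fold higher number from compound 1 to compound 3 (0.09 log units; within the scatter) and it is expected to stay small. Compound 3 is expected to read 9000 nM within an estimated range from 3500 nM to 23000 nM once it is tested.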

Compound 3, half-maximal inhibitory concentration: 11800 nM
For compound 3 the middle estimate is 1.3-fold (0.12 log units) below the measured one; the range from low to high includes it.
By their numbers in this assay, from the lowest: compounds 1, 2 and 3 (each within the scatter of the next).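

Among these compounds, compound 3 supplies the first single-change step in this set: in this assay, hydrogen in place of acetamido on the aromatic carbon ortho to a 4-fluorophenyl group and para to a large group gives a 1.6-fold higher number from compound 1 to compound 3 (0.20 log units; within the scatter) and lies within the scatter. Compound 1 and compound 3 therefore stand level, so on this core the read-out does not separate the acetamido group from hydrogen at this position, something compound 2 could not show because it differs from compound 1 in more than one place. No measurement bearing on this result is available to account for it.

The compounds shown place only acetamido and hydrogen at this position, so they leave open whether an amine, a carboxylic acid or a longer acyl chain on the same aromatic carbon would also stay level with compound 1 or move beyond the scatter. Among the compounds shown here, they also leave open whether the same swap would read alike on a core carrying other groups on the far aromatic ring, since this single pair is the only direct comparison.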